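A few compounds are considered here, and "the series" means these few. Any claim that something is new, unique, unknown or untested is made for them only; others in the source may bear on it.

Two compounds carry the shared core of compound 1 `Cc1c(-c2cc(-c3ccccc3)no2)cnn1C1CCNCC1` and compound 2 `Fc1ccc(-c2cc(-c3cnn(C4CCNCC4)c3)on2)c(Cl)c1`. In an assay on isolated protein for positive allosteric modulation of Neuronal acetylcholine receptor; alpha4/beta2 (Homo sapiens) (a higher number here means that more compound is needed for the effect, a lower number that less compound is needed), compound 1 gives 1200 nM, while compound 2 gives 220 nM. On these two numbers compound 2 stands at the low end: compound 1 sits at a higher value than compound 2, a gap that lies beyond the usual scatter of the assay. The two structures differ in more than one place, so the two values are shown side by side without a single structural step between them.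

Compound 3 `c1nn(C2CCNCC2)cc1-c1cc(C2CCCCC2)no1` has not been measured in this assay. Compared with compound 2, the change is this: cyclohexyl in place of 2-chloro-4-fluorophenyl on an aromatic carbon. For the measured compounds named here, no pair of measured compounds shows this kind of exchange, so the size of the step rests on judgement rather than on a measured precedent. An expected step from compound 2 to compound 3 of a 3.6-fold higher number from compound 2 to compound 3 (0.56 log units; beyond the scatter) is foreseen, toward a higher number. Compound 3 is therefore estimated at 800 nM in this assay, with a range from 250 nM to 2500 nM.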

Compound 3, half-maximal effective concentration: 4600 nM
Compound 3: middle estimate off by 5.8-fold (0.76 log units), on the low side; measured number outside the range, above it.
By their numbers in this assay, from the lowest: compound 2; then compound 1; then compound 3.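

In this assay, for the compounds shown here, the exchange of 2-chloro-4-fluorophenyl for cyclohexyl gives a 21-fold higher number from compound 2 to compound 3 (1.32 log units; beyond the scatter), the only step here between compounds that differ in one place, and a large one. It shows that this aromatic carbon, next to the ring nitrogen of the five-membered aromatic ring, is sensitive to the group it carries: both groups are six-membered rings with no hydrogen-bond donors, hydrogen-bond acceptors or net charge, yet the number moves well beyond the scatter. Nothing measured here accounts for the size of this step.

The exchange changes two things at once, as the ring stops being aromatic and the chlorine and fluorine leave, and the compounds shown do not separate these two changes; a plain phenyl on the core of compound 2 would speak to that question. As far as these compounds go, it also remains open how a pyridyl ring, a cyclopentyl ring or a 4-fluorophenyl group would read at this carbon in this assay, and so how much of the substituted phenyl ring is needed.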